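Long-chain furopyrimidinone nucleosides: toxicity stays beyond the limit

The source may report more compounds than this note shows. Statements on the series, on what has been measured and on what is new or still open speak of the compounds shown alone.

Measured compounds:
compound 1 `CCCCCCCC#Cc1cc2cn(COCCO)c(=O)nc2o1` gives > 50000 nM
compound 2 `CCCCCCCCCCc1cc2cn(COCCO)c(=O)nc2o1` gives > 200000 nM
compound 3 `CCCCCC#Cc1cc2cn(COCCO)c(=O)nc2o1` gives > 50000 nM

In a functional assay on HEL cells (Homo sapiens) (on this read-out lower numbers stand for higher toxicity in this test and higher numbers for lower toxicity in this test), compound 1 reaches only a limit of the test, > 50000 nM. Compound 3 likewise gives a limit, > 50000 nM. Compound 2 also gives a limit, > 200000 nM, in this assay. The change from compound 1 to compound 3 is hydrogen in place of ethyl on a saturated chain carbon, five bonds along the chain from a triple-bonded carbon; the step it made, a step that the two limits leave unreadable from compound 1 to compound 3, cannot be read, since both values sit at limits, (the limit of > 50000 nM in this assay, at which 2 of the 3 values shown sit). The unmeasured compound 4 `CCCCCCCCc1cc2cn(COCCO)c(=O)nc2o1` carries the same kind of change relative to compound 2, (hydrogen in place of ethyl on a saturated chain carbon, eight bonds along the chain from an aromatic carbon); here the place is eight bonds along the chain from an aromatic carbon rather than five bonds along the chain from a triple-bonded carbon. How the core of compound 1 differs from that of compound 2 is not broken down here. For compound 4 a step of a number no higher from compound 2 to compound 4 (the limit leaves the size open) is expected. This rests on compound 2, whose value > 200000 nM is a limit, and on (the limit of > 200000 nM in this assay, at which 1 of the 3 values shown sits). Compound 4 is estimated at 200000 nM, between 50000 nM and 500000 nM, and most likely again only a limit.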

Compound 4, half-maximal cytotoxic concentration: > 200000 nM
Compound 4: only a limit was reported (the forecaster's own chance of this, stated with the estimate: 85%); the middle value sits exactly at the limit.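

In this assay compound 4 gives > 200000 nM, which is a limit of the test. Compound 2 also stands at a limit, so no step can be read between compound 2 and compound 4. The compounds shown leave open whether shortening the chain changes toxicity in this assay at all, as none of them yields an actual number.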